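A Halogen Swap on the Core of Compound 3

This account rests on a few compounds, and the source may have more. Where it says the series, first, only, none or still open, it means among the compounds named here.

Of the compounds shown here, three have been measured in an assay on isolated protein for inhibition of Calpain-1 catalytic subunit (Sus scrofa); a higher number here means a weaker inhibitor, a lower number a stronger inhibitor. Compound 1 `O=C(O)/C(S)=C/c1c[nH]c2ccc(F)cc12` gives 930 nM. Compound 2 `O=C(O)/C(S)=C/c1ccc(I)cc1`, built on a different core, gives 5200 nM. Compound 3 `O=C(O)/C(S)=C/c1c[nH]c2c(F)cccc12` gives 110 nM, the lowest of the three numbers and therefore the strongest inhibitor so far: compound 1 comes nearest, and compound 2 lies furthest away, both beyond the usual scatter.

Compound 4 `O=C(O)/C(S)=C/c1c[nH]c2c(Br)cccc12` has not yet been measured. It differs from compound 3 in one place: bromo in place of fluoro on an aromatic carbon. Within the data shown here, nothing among the measured compounds shows what this swap does; compound 1 and compound 3 differ in where a fluoro sits on the shared core and not in which halogen is present, and compound 2 carries its iodo on another core. The expectation is therefore cautious: a halogen-for-halogen exchange on the same aromatic carbon is estimated to move the number only a little, possibly within the scatter, with a slight lean towards a lower value, so that the step from compound 3 to compound 4 is expected to be a 1.2-fold lower number from compound 3 to compound 4 (0.09 log units; within the scatter). Compound 4 is thus expected to give about 90 nM, with a likely range from 30 nM to 350 nM.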

Compound 4, half-maximal inhibitory concentration: 70 nM
Beside the measured number, compound 4's estimate is 1.3-fold (0.11 log units) above it; the measured number falls inside the stated range.
By their numbers in this assay, from the lowest: compounds 4 and 3 (each within the scatter of the next); then compound 1; then compound 2.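

In this assay, putting bromo in place of fluoro on this aromatic carbon gives a 1.6-fold lower number from compound 3 to compound 4 (0.20 log units; within the scatter), so the two compounds cannot be told apart in this test. Among these compounds, this is the first pair that differs only in which halogen is present, and it shows that this carbon of the shared core, ortho to a fused ring, can carry either fluoro or bromo with no change beyond the usual scatter between repeated measurements. No supporting information is available on why the two halogens give results that cannot be separated here.

Going by these compounds, it remains open whether this carbon would accept groups that are not halogens, such as a methoxy group, an amine or a nitrile, or whether a plain hydrogen there would give a similar number, which would show whether the halogen matters at all. Among the compounds shown here, it is also open whether the same exchange of fluoro for bromo would leave the number similarly unmoved at the other fluoro position, the one seen in compound 1.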